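A few compounds are considered here, and "the series" means these few. Any claim that something is new, unique, unknown or untested is made for them only; others in the source may bear on it.

Measured so far:
- compound 1, `Cc1cccc(NC(=O)CN2CCC(c3cccc(O)c3)CC2)c1`: 8 nM
- compound 2, `COc1ccccc1C1CCN(CNC(=O)c2cccc(C)c2)CC1`: 206 nM

Of the compounds shown here, two have been tested in a functional assay on HEK293 cells for agonist activity at D(4) dopamine receptor (Homo sapiens), read by FLIPR; on this read-out lower numbers stand for an effect already at smaller amounts and higher numbers for an effect only at larger amounts of compound. Compound 1 gives 8 nM and stands lowest of the two numbers. Compound 2 gives 206 nM, a markedly higher number that lies well beyond the usual scatter; the two structures differ in several places at once, so the comparison only shows that compound 1 acts at the smaller amount.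

The next compound, compound 3 with structure `Cc1cccc(NC(=O)CN2CCC(c3ccccc3C)CC2)c1`, is not yet measured. It keeps the core of compound 1 and changes one group: 2-methylphenyl in place of 3-hydroxyphenyl on a saturated ring carbon

Nothing measured here isolates this single change, so the expectation rests on compound 1 alone. Because compound 1 already sits at 8 nM, compound 3 is expected to stay in a nearby range, with a moderate step toward higher numbers, a 3.8-fold higher number from compound 1 to compound 3 (0.57 log units; beyond the scatter), that may or may not exceed the scatter. The estimate for compound 3 in this assay is 30 nM, with a plausible range from 6 nM to 150 nM.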

Compound 3, half-maximal effective concentration: 340 nM
Compound 3: the middle estimate sits 11-fold (1.05 log units) below what was measured, outside the stated range (above it).
By their numbers in this assay, from the lowest: compound 1; then compounds 2 and 3 (each within the scatter of the next).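

In this assay, putting 2-methylphenyl in place of 3-hydroxyphenyl on a saturated ring carbon gives a 43-fold higher number from compound 1 to compound 3 (1.63 log units; beyond the scatter) and is a large step, well beyond the scatter. Within the data shown here, this is the first pair that differs in one place only, so it shows that the group at this position matters greatly for this read-out, while the comparison between the two earlier compounds could not be tied to any single part of their structures. The two groups have the same count of heavy atoms, but the exchange removes the hydroxyl with its hydrogen-bond donor and acceptor and adds a methyl at the same time, and no measurement here explains why the number rises.

The compounds shown leave open whether the step follows from losing the hydroxyl, from adding the methyl, or from both, and a plain phenyl group would be the direct way to separate these. They also leave open how an amine or a carboxylic acid in place of the hydroxyl would behave at this position.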